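A Heteroaryl Swap on a Bitter Taste Receptor Antagonist

The source may report more compounds than this note shows. Statements on the series, on what has been measured and on what is new or still open speak of the compounds shown alone.

Measured so far, in a functional assay on cells for antagonist activity at taste receptor type 2 member 8 (Homo sapiens), read by FLIPR and calcium flux, with a stated time of 100 s; on this read-out lower numbers stand for stronger inhibition and higher numbers for weaker inhibition:
compound 1, `COc1cccc(C(=O)Nc2cnn(Cc3c(C)noc3C)c2)c1`, gives 700 nM
compound 2, `Cc1noc(C)c1Cn1cc(N2C(=O)CN(Cc3ccccc3)C2=O)cn1`, gives 200 nM

Compound 2 has the lowest of the two numbers in this assay, and its nearest neighbour, compound 1, sits at a higher number by a gap that goes beyond the usual scatter. Among the measured compounds shown here, the two compounds differ in more than one place, so the two values show only that compound 2 is the stronger inhibitor of the pair, not which part of the structure is responsible.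

Compound 3, `Cc1cc(CN2CC(=O)N(c3cnn(Cc4c(C)noc4C)c3)C2=O)n(C)n1`, has not yet been measured. It differs from compound 2 in one place: 1,3-dimethyl-1H-pyrazol-5-yl in place of phenyl on a saturated chain carbon bound to an amide-type nitrogen in a ring. For the measured compounds named here, no measured pair shows this change, so there is nothing to say how large its effect is. The expectation is a step of no clear size, a 1.5-fold higher number from compound 2 to compound 3 (0.18 log units; within the scatter), with the new number remaining close to that of compound 2. Compound 3 is therefore estimated at 300 nM in this assay, within a range from 100 nM to 900 nM.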

Compound 3, half-maximal inhibitory concentration: 200 nM
For compound 3 the middle estimate is 1.5-fold (0.18 log units) above the measured one; the range from low to high includes it.
By their numbers in this assay, from the lowest: compounds 2 and 3 (each within the scatter of the next); then compound 1.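

In this assay, among the compounds shown here, putting 1,3-dimethyl-1H-pyrazol-5-yl in place of phenyl on a saturated chain carbon bound to an amide-type nitrogen in a ring gives no change at the digits printed from compound 2 to compound 3 (within the scatter) and is the first single change that can be read at this position, since compound 1 and compound 2 differ in more than one place. The entering group is quite different on paper: a five-membered aromatic ring with 2 hetero atoms and 2 hydrogen-bond acceptors replaces a six-membered ring of carbon only with 0 hydrogen-bond acceptors, yet the two compounds remain within the scatter of each other, so this position accepts both groups in this assay. Nothing measured here explains why the two groups read alike.

The compounds shown carry only these two aromatic rings at this position, so it remains open whether a group of another kind, such as a carboxylic acid, an amine or a saturated piperidine ring, would be accepted as well. Going by these compounds, it also remains open how a longer chain between the ring and the amide-type nitrogen would read.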